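Adding a Second Fluorine to a Methylsulfonyl Biaryl Acid

This account rests on a few compounds, and the source may have more. Where it says the series, first, only, none or still open, it means among the compounds named here.

compound 1 `CSc1ccc(OCc2ccc(F)cc2F)c(C2=C(c3cccc(C(=O)O)c3)CCC2)c1`: < 3170 nM
compound 2 `CS(=O)(=O)c1ccc(OCc2ccc(F)cc2)c(C2=C(c3cccc(C(=O)O)c3)CCC2)c1`: < 3170 nM

In an assay on isolated protein for inhibition of prostaglandin E2 receptor EP3 subtype (Homo sapiens) (a higher number here means a weaker inhibitor, a lower number a stronger inhibitor), compound 2 gives < 3170 nM, which is a limit of the assay and not a number. Compound 1 likewise gives only a limit in this assay, namely < 3170 nM. The one figure so far is thus (the limit of < 3170 nM in this assay, at which 2 of the 2 values shown sit). Compound 3 `CS(=O)(=O)c1ccc(OCc2ccc(F)cc2F)c(C2=C(c3cccc(C(=O)O)c3)CCC2)c1` differs from compound 2 by fluoro in place of hydrogen on an aromatic carbon. Within the data shown here, no measured step of this kind is available, so no change beyond the scatter is expected in either direction. Compound 3 is estimated at 300 nM, with a range of 30 nM to 3000 nM. The expected step is a step that the limit leaves unreadable from compound 2 to compound 3.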

Compound 3, half-maximal inhibitory concentration: < 3170 nM
Compound 3: a limit, no number; the forecaster's own chance of this, stated with the estimate: 70%; the middle value is on the limit's open side.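

The steps from compound 1 and from compound 2 to compound 3 cannot be read, as all three values are limits and not numbers: the limit of < 3170 nM in this assay, at which 3 of the 3 values shown sit. Going by these compounds, whether fluoro in place of hydrogen, or methylsulfonyl in place of methylsulfanyl, shifts inhibition remains open.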